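The source may hold more compounds than are shown below. What is called first, only, known or untested is meant among the compounds shown, and "the series" means these compounds.

Measured compounds:

Compound 1 `CC(=O)OC(C)n1cnc2c(Cl)nc(N)nc21`: in a functional assay on CCRF-CEM cells (Homo sapiens) for inhibition (a lower number here means a stronger inhibitor, a higher number a weaker inhibitor), compound 1 gives > 500000 nM, which is a limit of the assay and not a number.
Compound 2 `CC(O)n1cnc2c(N)nc(I)nc21`: in this assay compound 2 gives 465000 nM.
Compound 3 `Nc1nc(I)nc2c1ncn2OCCO`: in this assay compound 3 gives > 500000 nM, again a limit of the assay rather than a number.

Compound 3 therefore stands only at a limit. Two of the three values shown sit at that same limit (the limit of > 500000 nM in this assay, at which 2 of the 3 values shown sit), and compound 2 alone gives a number, which lies in the same weak region. Going by the values given here, the single measured step, an at least 1.0-fold higher number from compound 2 to compound 3 (0.03 log units; that floor lies within the scatter), runs from a number to a limit and is recorded as a floor within the scatter, so it carries no direction of its own.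

Compound 4 `COc1nc(I)nc2c1ncn2OCCO` differs from compound 3 by methoxy in place of amino on an aromatic carbon. Among the compounds with values here, no measured step touches this position; the step from compound 2 to compound 3 bears on it only in showing that a change on the ring nitrogen left the value at the limit. The expectation in this assay is therefore no change beyond the scatter, and the step of a number no higher from compound 3 to compound 4 (the limit leaves the size open) is expected to be flat. Compound 4 is estimated at 500000 nM, with a range from 150000 nM to 2000000 nM, most likely reported again only as a limit.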

Compound 4, half-maximal inhibitory concentration: > 500000 nM
Compound 4 ended at the assay's limit; the forecaster's own chance of this, stated with the estimate: 80%; the middle value sits exactly at the limit.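

Compound 3 and compound 4 both stand at a limit in this assay, so no step can be read between them for methoxy in place of amino on an aromatic carbon. The compounds shown leave open how these two groups compare, since most values rest at one limit: the limit of > 500000 nM in this assay, at which 3 of the 4 values shown sit.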